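From acetyl to dimethylcarbamoyl: one small change

This account rests on a few compounds, and the source may have more. Where it says the series, first, only, none or still open, it means among the compounds named here.

The starting point is compound 1 `CC(=O)N(C)CC#CCN1CCCC1`, tested in a functional assay on the whole organism for antagonist activity, with Mus musculus as the target; a higher number here means that more compound is needed for the effect, a lower number that less compound is needed. Compound 1 gives > 10 mg/kg, which is a limit of the assay and not a number. Going by these compounds, its true dose therefore remains unknown.

For the measured compounds named here, the only exact number so far comes from compound 2 `CCOC(=O)N(C)C(C)C#CCn1cncc1C`, which gives 9.7 mg/kg. Going by the values given here, no two measured compounds here differ in just one place, so the data show no direct example of what a single change does.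

The next compound is compound 3 `CN(C)C(=O)N(C)CC#CCN1CCCC1`. It keeps the core of compound 1 and makes one edit: dimethylamino in place of methyl on a carbonyl carbon. In words, dimethylamino stands in place of methyl on a carbonyl carbon, which turns acetyl into dimethylcarbamoyl.

Among the compounds with values here, with no measured step as a guide, only a modest shift is expected, with a slight lean towards needing more compound. The expected size is a step that the limit leaves unreadable from compound 1 to compound 3, and this estimate is uncertain. The assay may well report only a limit again. For compound 3, the estimated dose is 15 mg/kg, with an expected range from 5 mg/kg to 45 mg/kg.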

Compound 3, dose for half-maximal effect: 6.6 mg/kg
Beside the measured number, compound 3's estimate is 2.3-fold (0.36 log units) above it; the measured number falls inside the stated range.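

Swapping methyl for dimethylamino on a carbonyl carbon, which turns acetyl into dimethylcarbamoyl, gives the first exact number on the core of compound 1: in this assay compound 3 gives 6.6 mg/kg as its dose for half-maximal effect. Compound 1 gives > 10 mg/kg, which is a limit of the assay and not a number. This single change therefore reads as an at least 1.5-fold lower number from compound 1 to compound 3 (0.18 log units; that floor lies within the scatter), so the direction points towards less compound being needed, but the true size stays hidden because the starting compound has no exact value: the limit of > 10 mg/kg in this assay, at which 1 of the 3 values shown sits.

Going by these compounds, whether another group on the same carbonyl carbon, such as the smaller methylamino, the longer diethylamino or a plain ethyl chain, would shift the dose further stays open, as does the real size of the step from acetyl to dimethylcarbamoyl. Compound 2 differs from compound 3 in more than one place, so it cannot show how much of its dose comes from the group on the carbonyl carbon.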